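Isobutyl for isopropyl across two cores

A few compounds are considered here, and "the series" means these few. Any claim that something is new, unique, unknown or untested is made for them only; others in the source may bear on it.

The series is read in a functional assay on RAW264.7 cells (Mus musculus) for inhibition, read by microscopy and resazurin assay, with a stated time of 72 h; on this read-out higher numbers stand for weaker inhibition and lower numbers for stronger inhibition. Compound 2 `C=CCONC(=O)CN1C(=O)S/C(=C\c2cccc(C(=O)N[C@H](C(=O)OC)C(C)C)c2)C1=O` carries an isopropyl group on a saturated chain carbon bound to an amide-type nitrogen and a carbonyl carbon; in this assay compound 2 reaches only the limit > 128000 nM, which is a limit of the assay and not a number. Compound 1 `C=CCONC(=O)CN1C(=O)S/C(=C\c2cccc(C(=O)N[C@@H](CC(C)C)C(=O)OC)c2)C1=O` is the isobutyl counterpart, and in this assay compound 1 likewise returns only the limit > 128000 nM. The change from compound 2 to compound 1 is isobutyl in place of isopropyl on a saturated chain carbon bound to an amide-type nitrogen and a carbonyl carbon. Its size is a step that the two limits leave unreadable from compound 2 to compound 1, both ends of the step sitting at the limit of > 128000 nM in this assay, at which 3 of the 3 values shown sit.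

Compound 3 `CC(C)[C@H](NC(=O)CNC(=O)c1ccn(CC(=O)NOCc2ccccc2)c1)C(=O)O` rests on a second core; the difference between the two cores is not broken down here. In this assay compound 3 again gives only the limit > 128000 nM. Compound 4 `CC(C)C[C@H](NC(=O)CNC(=O)c1ccn(CC(=O)NOCc2ccccc2)c1)C(=O)O` has not yet been measured. It differs from compound 3 by isobutyl in place of isopropyl on a saturated chain carbon bound to an amide-type nitrogen and a carbonyl carbon, the same change as that from compound 2 to compound 1, at the same place.

For compound 4 the step from compound 3 is expected to be a step that the limit leaves unreadable from compound 3 to compound 4. This expectation rests on the step from compound 2 to compound 1, which stayed unreadable at the limit of > 128000 nM in this assay, at which 3 of the 3 values shown sit, with all three measured values at that limit. Compound 4 is therefore expected near 200000 nM, in a range from 100000 nM to 600000 nM, and most probably the assay will again report only a limit rather than a number.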

Compound 4, half-maximal inhibitory concentration: > 128000 nM
Compound 4: no number, only a limit; the forecaster's own chance of this, stated with the estimate: 90%; the middle value lies beyond the limit too.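

In this assay compound 4 gives > 128000 nM, which is a limit of the assay and not a number. No step can be read from compound 3 to compound 4, with both compounds at the same limit: the limit of > 128000 nM in this assay, at which 4 of the 4 values shown sit. The compounds shown leave open whether isobutyl in place of isopropyl alters inhibition on either core, and what the actual value of any of the four compounds is.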